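Bromo in place of methoxy on the shared core

The source may hold more compounds than are shown below. What is called first, only, known or untested is meant among the compounds shown, and "the series" means these compounds.

Two compounds of the series have readings in a physicochemical assay for solubility, at pH 6.8; a lower number here means a less soluble compound, a higher number a more soluble compound. Compound 2 (`CC(C)c1c(COc2cccc(OCC3CCOCC3)c2)[nH]c2ccccc2c1=O`) gives 3000 nM. Compound 1 (`COc1ccc2[nH]c(COc3cccc(OCC4CCOCC4)c3)c(C)c(=O)c2c1`) gives < 1000 nM, which is a limit of the assay and not a number. Among the measured compounds shown here, no measured pair differs in one place only, so the series offers no direct precedent for the change at issue.

Compound 3 (`Cc1c(COc2cccc(OCC3CCOCC3)c2)[nH]c2ccc(Br)cc2c1=O`) has not yet been measured. It differs from compound 1 by bromo in place of methoxy on an aromatic carbon.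

No step beyond the usual scatter is expected in this assay, and neither direction is favoured. The expected step is a step that the limit leaves unreadable from compound 1 to compound 3. This expectation starts from compound 1 at < 1000 nM, a limit rather than a number, so compound 3 may also be reported only as a limit. For compound 3 the estimate is 700 nM, with an expected range of 250 nM to 2000 nM.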

Compound 3, solubility: < 1000 nM
Compound 3: only a limit was reported; the forecaster's own chance of this, stated with the estimate: 60%; the middle value does not contradict the limit.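

In this assay compound 3 gives < 1000 nM, a limit of the assay and not a number. Compound 1 also stands at a limit, so no step can be read between compound 1 and compound 3: the limit of < 1000 nM in this assay, at which 2 of the 3 values shown sit.

The compounds shown leave open where the actual values of compound 1 and compound 3 lie, and whether bromo in place of methoxy shifts the reading at all.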